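Methyl added to a chloro-bearing analogue: expected lipophilicity

The compounds below may be only part of what the source reports. "The series", "measured", "known", "first", "only" and "open" are said of these compounds alone.

The shared core is carried by three measured compounds. Compound 1 `O=C(NC(=S)Nc1ccccc1)Nc1ccc2c(c1)C(=O)C(=O)N2Cc1ccccc1` gives 2.48 in a physicochemical assay for lipophilicity, in phosphate buffer, measured as octanol-water partition; a higher number here means a more lipophilic compound, a lower number a more polar compound. Compound 2 `Cc1ccc(NC(=S)NC(=O)Nc2ccc3c(c2)C(=O)C(=O)N3Cc2ccccc2)cc1` gives 2.96 in this assay, and compound 3 `O=C(NC(=S)Nc1ccccc1)Nc1ccc2c(c1)C(=O)C(=O)N2Cc1ccccc1Cl` gives 3.18. Compound 3 stands at the upper end of these three numbers: its value and that of compound 2 lie within the scatter of each other, whereas the step of a number 0.70 log units higher from compound 1 to compound 3 (beyond the scatter) is beyond it, as is the step of a number 0.48 log units higher from compound 1 to compound 2 (beyond the scatter).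

Compound 4 `Cc1cccc(NC(=S)NC(=O)Nc2ccc3c(c2)C(=O)C(=O)N3Cc2ccccc2Cl)c1` differs from compound 3 in one place: methyl in place of hydrogen on an aromatic carbon. The place is meta to a large group on the phenyl of the thiourea side, so the change reads anilino to (3-methylphenyl)amino.

The measured step that bears on this is a number 0.48 log units higher from compound 1 to compound 2 (beyond the scatter), where the same methyl for hydrogen exchange on the same ring raised the number by a modest amount beyond the scatter. For the measured compounds named here, no measured pair tests a methyl and a chloro together, so the expectation rests on that single step alone. Compound 4 is therefore expected to lie above compound 3 by a step of a number 0.48 log units higher from compound 3 to compound 4 (beyond the scatter), in the direction of a more lipophilic compound. Compound 4 is estimated at 3.66, with a range from 3.3 to 4.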

Compound 4, partition coefficient: 3.72
Estimate against measurement, compound 4: 0.06 log units below; the range from low to high includes it.
By their numbers in this assay, from the lowest: compound 1; then compounds 2 and 3 (each within the scatter of the next); then compound 4.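

In this assay, the methyl in place of hydrogen now gives a number 0.54 log units higher from compound 3 to compound 4 (beyond the scatter), a modest step beyond the scatter, at the place meta to a large group and on a compound that already carries the chloro. The earlier compounds shown here showed this exchange only without the chloro, as a number 0.48 log units higher from compound 1 to compound 2 (beyond the scatter), so the new step adds a second case in which the exchange raises the number, on a different background and at this particular place, and the two steps are printed as modest alike. No measurement shown here explains why the number rises with this change at this place, and these two steps alone establish no general rule for the exchange.

What the compounds shown leave open is how the number would respond if the methyl at this place on the phenyl of the thiourea side gave way to a methoxy group, an amine, a carboxylic acid or a longer chain such as propyl. They also leave open whether the step would keep its direction and size with a group other than the chloro on the benzyl ring, such as a fluoro or a nitrile.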